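A few compounds are considered here, and "the series" means these few. Any claim that something is new, unique, unknown or untested is made for them only; others in the source may bear on it.

Measured so far in an ADME assay on WI-38 cells (Homo sapiens) for inhibition, read by MTT assay, with a stated time of 72 h; on this read-out lower numbers stand for stronger inhibition and higher numbers for weaker inhibition:

Compound 1, `Cc1ccc(C(=O)OC2(C(=O)Nc3ccc([N+](=O)[O-])cc3)CCCCC2)cc1`, compound 1 gives 32 nM.
Compound 2, `O=C(OC1(C(=O)Nc2ccc([N+](=O)[O-])cc2)CCCCC1)c1ccc(Cl)cc1`, compound 2 gives 355 nM.
Compound 3, `O=C(OC1(C(=O)Nc2ccc([N+](=O)[O-])cc2)CCCCC1)c1ccccc1I`, compound 3 gives 396 nM.

Compound 1 stands at the lowest number of the three, and both other compounds lie well away from it: an 11-fold higher number from compound 1 to compound 2 (1.05 log units; beyond the scatter) and a 12-fold higher number from compound 1 to compound 3 (1.09 log units; beyond the scatter). Between compound 2 and compound 3 the numbers are close, a 1.1-fold higher number from compound 2 to compound 3 (0.05 log units; within the scatter).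

Compound 4, `O=C(OC1(C(=O)Nc2ccc([N+](=O)[O-])cc2)CCCCC1)c1ccc([N+](=O)[O-])cc1`, has not yet been measured in this assay. It differs from compound 1 in one place: nitro in place of methyl on an aromatic carbon.

For the measured compounds named here, two measured steps bear on this change. Both start from compound 1 and both replace or remove the methyl on the aryl ester; both gave a large rise in the number, from compound 1 to compound 2 and from compound 1 to compound 3. Going by the values given here, no measured compound carries a nitro in that spot, so the size of the step for this particular group is unknown, but the two known steps point the same way.

Compound 4 is therefore expected to sit at a higher number than compound 1, with a step of about a 9.4-fold higher number from compound 1 to compound 4 (0.97 log units; beyond the scatter). The estimate for compound 4 in this assay is 300 nM, expected to fall between 80 nM and 1200 nM.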

Compound 4, half-maximal inhibitory concentration: 761 nM
Estimate against measurement, compound 4: 2.5-fold (0.40 log units) below, within the range that was stated.
By their numbers in this assay, from the lowest: compound 1; then compounds 2, 3 and 4 (each within the scatter of the next, the first and the last beyond it).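

Putting a nitro in place of the methyl on the aromatic carbon para to a large group raises the number in this assay, a 24-fold higher number from compound 1 to compound 4 (1.38 log units; beyond the scatter), so a third replacement now points the same way as the chloro and the 2-iodophenyl changes, and methyl remains the only group shown here that gives a low number. The replacements can also be compared with one another: a 2.1-fold higher number from compound 2 to compound 4 (0.33 log units; beyond the scatter) is a modest step that separates nitro from chloro on this carbon, whereas a 1.9-fold higher number from compound 3 to compound 4 (0.28 log units; within the scatter) does not separate the 4-nitrophenyl compound from the 2-iodophenyl compound. Nothing available here explains why the methyl compound stands apart from the other three.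

On these data alone, it remains open whether the low number belongs to methyl alone or would also be seen with hydrogen, an ethyl group or a methoxy group on the same carbon. As far as these compounds go, it is also open whether a methyl group elsewhere on this ring would keep the number low, and whether changes to the cyclohexane ring or the 4-nitrophenyl amide would matter as much as this one.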